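The source may hold more compounds than are shown below. What is called first, only, known or untested is meant among the compounds shown, and "the series" means these compounds.

Measured so far in a functional assay on cells (leukaemia cell line, Homo sapiens) for inhibition, read by sulforhodamine B assay, with a stated time of 48 h; on this read-out lower numbers stand for stronger inhibition of growth and higher numbers for weaker inhibition of growth:
- Compound 1 `Cc1ccc(NS(=O)(=O)c2ccc(-c3cnc(C4CC4)o3)cc2)cc1C`: > 100000 nM (a limit)
- Compound 2 `O=S(=O)(Nc1cc(Cl)ccc1Cl)c1ccc(-c2cnc(C3CC3)o2)cc1`: > 100000 nM (a limit)
- Compound 3 `COc1cc(NS(=O)(=O)c2ccc(-c3cnc(C4CC4)o3)cc2)ccc1F`: 75700 nM

Compound 3 is the only one of these with an actual number. The other two stop at the limit of > 100000 nM in this assay, at which 2 of the 3 values shown sit.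

Compound 4 `Cc1cc(Cl)ccc1NS(=O)(=O)c1ccc(-c2cnc(C3CC3)o2)cc1` carries 4-chloro-2-methylphenyl in place of 4-fluoro-3-methoxyphenyl on a sulfonamide nitrogen.

Three measured steps changed this same group: a step that the two limits leave unreadable from compound 1 to compound 2, an at least 1.3-fold lower number from compound 1 to compound 3 (0.12 log units; that floor lies within the scatter) and an at least 1.3-fold lower number from compound 2 to compound 3 (0.12 log units; that floor lies within the scatter). None shows a change beyond the scatter, and none of the three compounds reads far from the limit.

The expected result is a 1.3-fold higher number from compound 3 to compound 4 (0.12 log units; within the scatter), with no step beyond the scatter in either direction.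

For compound 4 the estimated value is 100000 nM, with an expected range of 60000 nM to 200000 nM.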

Compound 4, concentration for total growth inhibition: 54700 nM
Beside the measured number, compound 4's estimate is 1.8-fold (0.26 log units) above it; measured number outside the range, below it.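

In this assay, the change of 4-fluoro-3-methoxyphenyl to 4-chloro-2-methylphenyl on the sulfonamide nitrogen gives a 1.4-fold lower number from compound 3 to compound 4 (0.14 log units; within the scatter), so two different substituted phenyl groups at this place now read alike. The steps with this new group, an at least 1.8-fold lower number from compound 2 to compound 4 (0.26 log units; that floor lies within the scatter) and an at least 1.8-fold lower number from compound 1 to compound 4 (0.26 log units; that floor lies within the scatter), also show no change beyond the scatter. Compound 1 and compound 2 remain limits, not numbers: the limit of > 100000 nM in this assay, at which 2 of the 4 values shown sit.

From the compounds shown here alone, whether any group on this nitrogen can bring the number far down stays open. A phenyl carrying a carboxylic acid or an amine, or a longer alkyl chain in place of the phenyl, could test this.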